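A few compounds are considered here, and "the series" means these few. Any claim that something is new, unique, unknown or untested is made for them only; others in the source may bear on it.

For the measured compounds named here, in a functional assay on SK-OV-3 cells (Homo sapiens) for antiproliferative activity, read by MTT assay, with a stated time of 24 h (on this read-out lower numbers stand for stronger inhibition and higher numbers for weaker inhibition), compound 1 `COc1ccc(C(=O)/C=C/c2ccc(N(C)C)cc2)c2c1C=CC(C)(C)O2` gives 2750 nM, the lower of the two numbers measured so far, while compound 2 `COc1ccc(C(=O)/C=C/c2cccc([N+](=O)[O-])c2)c2c1C=CC(C)(C)O2` gives 9720 nM. Compound 1 is therefore the stronger inhibitor of this pair, and it serves as the starting point here. The next compound, compound 3 `COc1ccc(C(=O)/C=C/c2ccc(C(F)(F)F)cc2)c2c1C=CC(C)(C)O2`, keeps the shared core and the chain but changes one group: trifluoromethyl in place of dimethylamino on an aromatic carbon. In words, trifluoromethyl stands in place of dimethylamino on an aromatic carbon, para to a large group. Going by the values given here, only one measured step bears on this change. Compound 2 also lacks the dimethylamino group, and its step is a 3.5-fold higher number from compound 1 to compound 2 (0.55 log units; beyond the scatter), a modest change beyond the scatter. Among the compounds with values here, it is only a loose guide, since compound 2 carries a nitro group and no measured compound carries trifluoromethyl. A step of similar or somewhat smaller size towards a higher number is therefore expected in this assay, although a result within the scatter cannot be excluded. The estimated step is a 2.4-fold higher number from compound 1 to compound 3 (0.37 log units; beyond the scatter). For compound 3 the expected value is 6500 nM, with an estimated range from 2500 nM to 17000 nM.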

Compound 3, half-maximal inhibitory concentration: > 10000 nM
Compound 3: no number, only a limit; the forecaster's own chance of this, stated with the estimate: 5%; at least 1.5-fold (0.18 log units) between middle value and limit.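

In this assay compound 3 gives > 10000 nM, which is a limit of the assay and not a number. Here the group changes while its place on the aromatic ring stays the same, and the result is an at least 3.6-fold higher number from compound 1 to compound 3 (0.56 log units; beyond the scatter), so replacing dimethylamino with trifluoromethyl is on its own enough to give a change beyond the scatter, whereas the earlier step to compound 2 changed the group and its place on the ring together. On these data alone, the step therefore fixes only a minimum, and its full size stays unknown, with the reading ending at the top of the measured range: the limit of > 10000 nM in this assay, at which 1 of the 3 values shown sits.

The compounds shown leave open whether it is dimethylamino itself that matters at this place, since a smaller amine such as methylamino, a cyclic amine such as pyrrolidine, or a methoxy group could each show whether the value of compound 1 is kept. They also leave open how a nitro group would read at this same place, which would separate the effect of the group from that of its place in compound 2.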